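This account rests on a few compounds, and the source may have more. Where it says the series, first, only, none or still open, it means among the compounds named here.

Measured compounds in a functional assay on DU-145 cells (Homo sapiens) for cytotoxicity, read by MTT assay; on this read-out lower numbers stand for stronger inhibition and higher numbers for weaker inhibition:
Compound 1, `CC[C@](C)(O)CC(=O)O[C@H](CC=C(C)C)C1=CC(=O)c2c(O)ccc(O)c2C1=O`: 20500 nM
Compound 2, `CC(C)=CC[C@@H](OCC(C)O)C1=CC(=O)c2c(O)ccc(O)c2C1=O`: 16100 nM
Compound 3, `CC(C)=CC[C@@H](OC(=O)C1CCCCO1)C1=CC(=O)c2c(O)ccc(O)c2C1=O`: 24700 nM

The three numbers lie close together. Compound 1 sits in the middle of them, and both of its steps, a 1.2-fold higher number from compound 1 to compound 3 (0.08 log units; within the scatter) and a 1.3-fold lower number from compound 1 to compound 2 (0.10 log units; within the scatter), stay within the usual scatter of this assay, as does the step of a 1.5-fold higher number from compound 2 to compound 3 (0.19 log units; within the scatter). On these numbers none of the three compounds can be called stronger or weaker than another.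

Compound 4, `CC(C)=CC[C@@H](OC(=O)c1ccoc1)C1=CC(=O)c2c(O)ccc(O)c2C1=O`, has not yet been measured. Compared with compound 1 the change is furan-3-yl in place of 2-hydroxy-2-methylbutyl on a carbonyl carbon. The shared core and the attached chain are untouched; only the group on the carbonyl carbon of the ester is exchanged.

The step that bears most directly on this change is a 1.2-fold higher number from compound 1 to compound 3 (0.08 log units; within the scatter), where a different group was likewise put on that carbonyl carbon and the number moved only within the scatter. The step of a 1.5-fold higher number from compound 2 to compound 3 (0.19 log units; within the scatter), which also alters what sits on the oxygen on the saturated carbon, was equally small. On that basis no step beyond the scatter is expected for compound 4, in either direction, so that a 1.0-fold higher number from compound 1 to compound 4 (0.01 log units; within the scatter) is the estimated step.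

Compound 4 is therefore expected to give about 21000 nM in this assay, with a likely range from 9000 nM to 50000 nM.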

Compound 4, half-maximal inhibitory concentration: > 100000 nM
Compound 4: a limit, no number (the forecaster's own chance of this, stated with the estimate: 10%); middle value at least 4.7-fold (0.67 log units) away from the limit.
By their numbers in this assay, from the lowest: compounds 2, 1 and 3 (each within the scatter of the next). At a limit, above all of these: compound 4.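

In this assay, compound 4 gives no number, only a limit of the assay: the limit of > 100000 nM in this assay, at which 1 of the 4 values shown sits.

Even so, all three steps to it lie beyond the scatter: an at least 4.8-fold higher number from compound 1 to compound 4 (0.68 log units; beyond the scatter), an at least 4.0-fold higher number from compound 3 to compound 4 (0.60 log units; beyond the scatter) and an at least 6.2-fold higher number from compound 2 to compound 4 (0.79 log units; beyond the scatter). Going by these compounds alone, the earlier compounds suggested that the group on the carbonyl carbon could be exchanged with little consequence, but compound 4 shows that this position does respond to the change: with 2-hydroxy-2-methylbutyl in compound 1 and oxan-2-yl in compound 3 the numbers lie within the scatter of each other, whereas furan-3-yl, the only one of these groups with an aromatic ring, gives clearly weaker inhibition.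

As far as these compounds go, because compound 4 is read only at a limit, the true size of its steps remains unknown, and one compound cannot show whether the loss belongs to the furan-3-yl group alone or to aromatic rings on this carbonyl carbon in general. A phenyl or pyridine ring, or the saturated oxolan-3-yl ring, in the same place would help separate these possibilities.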